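From Compound 2 to Compound 4 in Rat Aorta

A few compounds are considered here, and "the series" means these few. Any claim that something is new, unique, unknown or untested is made for them only; others in the source may bear on it.

Measured compounds:
compound 1, `COc1ccc(-c2nc(/N=C(\N)N(C)C)sc2-c2ccc(OC)cc2)cc1`, 4.8 uM
compound 2, `C/N=C(/NC)Nc1nc(-c2ccc(OC)cc2)c(-c2ccc(OC)cc2)s1`, 2.4 uM
compound 3, `COc1ccc(-c2nc(CN)sc2-c2ccc(OC)cc2)cc1`, 7.7 uM

In a functional assay (aorta) with Rattus norvegicus as the target (a higher number here means that more compound is needed for the effect, a lower number that less compound is needed), compound 2 gives 2.4 uM. Its gap to compound 1, a 2.0-fold lower number from compound 1 to compound 2 (0.30 log units; within the scatter), is within the scatter, while its gap to compound 3, a 3.2-fold higher number from compound 2 to compound 3 (0.51 log units; beyond the scatter), is beyond it, so compound 2 is not separated from compound 1 on these numbers.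

Compound 4, `COc1ccc(-c2nc(C(=O)N=C(N)N)sc2-c2ccc(OC)cc2)cc1`, is not yet measured. It differs from compound 2 by a group of 6 heavy atoms (2 carbon, 3 nitrogen, 1 oxygen; no ring) in place of a group of 6 heavy atoms (3 carbon, 3 nitrogen; no ring), on an aromatic carbon.

All three measured steps change the same carbon of the shared core. Two of them, a 2.0-fold lower number from compound 1 to compound 2 (0.30 log units; within the scatter) and a 1.6-fold higher number from compound 1 to compound 3 (0.21 log units; within the scatter), stay within the scatter, and the third, a 3.2-fold higher number from compound 2 to compound 3 (0.51 log units; beyond the scatter), is only modest. Nothing measured tests the entering group itself, so the reference is this spread of small steps. Compound 4 is therefore expected to give 4 uM, in a range of 1.5 uM to 12 uM. Among the measured compounds shown here, that estimate means an expected 1.7-fold higher number from compound 2 to compound 4 (0.22 log units; within the scatter), a step that is not expected to clear the scatter, leaning toward a slightly higher number because compound 2 gives 2.4 uM and the only step beyond the scatter, a 3.2-fold higher number from compound 2 to compound 3 (0.51 log units; beyond the scatter), ran upward.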

Compound 4, concentration for half-maximal effect: > 100 uM
Compound 4 gave a limit, no number (the forecaster's own chance of this, stated with the estimate: 5%); middle value at least 25-fold (1.39 log units) from the limit.
By their numbers in this assay, from the lowest: compounds 2, 1 and 3 (each within the scatter of the next, the first and the last beyond it). At a limit, above all of these: compound 4.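

In this assay compound 4 stands at a limit and not at a number: the limit of > 100 uM in this assay, at which 1 of the 4 values shown sits. The earlier steps shown here at this aromatic carbon were small or modest, whereas this change gives an at least 41-fold higher number from compound 2 to compound 4 (1.61 log units; beyond the scatter), and the other two measured compounds give an at least 20-fold higher number from compound 1 to compound 4 (1.31 log units; beyond the scatter) and an at least 12-fold higher number from compound 3 to compound 4 (1.11 log units; beyond the scatter), so the position does not accept every group alike. Heavy-atom count does not sort these results: the groups of compound 2 and compound 4 match in that count and in their hydrogen-bond donors and acceptors, differing in an oxygen in place of a carbon and in their double bonds outside aromatic rings, while compound 3, with its group of 2 heavy atoms, keeps a measured value.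

The compounds shown do not separate the carbonyl on the ring carbon from the rest of the entering group as the source of this large step. As far as these compounds go, whether a carboxylic acid, a simple amide or a longer chain on this carbon would behave like compound 4 stays open.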